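The source may hold more compounds than are shown below. What is called first, only, known or untested is meant among the compounds shown, and "the series" means these compounds.

Of the compounds shown here, three have so far been measured in an assay on isolated protein (Bos taurus) for inhibition of geranylgeranyl transferase type-1 subunit beta (Homo sapiens); on this read-out lower numbers stand for stronger inhibition and higher numbers for weaker inhibition. Compound 1 `Cn1cncc1C(OCc1ccc(C#N)cc1)c1ccc(C#N)c(-c2cccc3cccnc23)c1` gives 103 nM in this assay, compound 2 `Cn1cncc1C(OCc1ccc(C#N)cc1-c1cccc(Cl)c1)c1ccc(C#N)nc1` gives 8620 nM, and compound 3 `Cn1cncc1C(OCc1ccc(C#N)nc1-c1ccc(OC(F)(F)F)cc1)c1ccc(C#N)cc1` gives 1200 nM. Compound 3 thus holds the second highest of the three numbers: it sits between compound 1 and compound 2, and both gaps lie beyond the scatter of repeated measurements, the gap to compound 2 being the smaller of the two. No two of the measured compounds differ in only one place, so no isolated step can be read from them.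

Compound 4 `Cn1cncc1C(OCc1ccc(C#N)nc1-c1cc(Cl)cc(Cl)c1)c1ccc(C#N)cc1` is the next compound to be measured in this assay. It differs from compound 3 in a single respect: 3,5-dichlorophenyl in place of 4-(trifluoromethoxy)phenyl on an aromatic carbon. Within the data shown here, none of the measured pairs isolates such an exchange of one aryl group for another, and compound 2, the only other compound carrying a chlorinated ring, differs from compound 3 in further places as well, so its number cannot be tied to that ring alone. On this basis the author expects the step from compound 3 to compound 4, a 1.3-fold higher number from compound 3 to compound 4 (0.10 log units; within the scatter), to be small, without a clear direction and not beyond the scatter. Compound 4 is therefore estimated at 1500 nM in this assay, within a range from 400 nM to 6000 nM.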

Compound 4, half-maximal inhibitory concentration: 1400 nM
For compound 4 the middle estimate is 1.1-fold (0.03 log units) above the measured one; the range from low to high includes it.
By their numbers in this assay, from the lowest: compound 1; then compounds 3 and 4 (each within the scatter of the next); then compound 2.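

In this assay, among these compounds, 3,5-dichlorophenyl in place of 4-(trifluoromethoxy)phenyl gives a 1.2-fold higher number from compound 3 to compound 4 (0.07 log units; within the scatter), the first step that isolates a single exchange. At this place, on an aromatic carbon next to the ring nitrogen, one substituted phenyl group can thus replace another while the two numbers stay within the scatter of each other, although the groups differ in what they carry: the leaving group has more heavy atoms, along with oxygen, fluorine and a hydrogen-bond acceptor, while the entering group has two chlorine atoms and no acceptor. Nothing available here bears on why these two groups read alike.

On these data alone, it remains open whether this tolerance extends to a phenyl ring carrying an amine or a carboxylic acid, or to a non-aromatic group such as a longer alkyl chain at the same place. As far as these compounds go, it is also open whether the same exchange would read alike on another core, such as that of compound 1, since this single step comes from one pair only.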